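A few compounds are considered here, and "the series" means these few. Any claim that something is new, unique, unknown or untested is made for them only; others in the source may bear on it.

Series notes. In a functional assay on LN-229 cells (Homo sapiens) for antiproliferative activity, with a stated time of 72 h (on this read-out lower numbers stand for stronger inhibition and higher numbers for weaker inhibition), compound 1 `CCCC#Cc1cc([C@@H]2O[C@H](CO)[C@@H](O)[C@H]2O)n2ncnc(N)c12` gives 40 nM. Compound 2 `Nc1ncnn2c([C@@H]3O[C@H](CO)[C@@H](O)[C@H]3O)cc(C#Cc3ccccc3)c12` gives 88000 nM, which is a 2200-fold higher number from compound 1 to compound 2 (3.34 log units; beyond the scatter). Compound 3 `Nc1ncnn2c([C@@H]3O[C@H](CO)[C@@H](O)[C@H]3O)cc(-c3ccccc3F)c12` gives only a limit of the assay, > 100000 nM, namely (the limit of > 100000 nM in this assay, at which 1 of the 3 values shown sits). Compound 3 therefore stands far from compound 1, by an at least 2500-fold higher number from compound 1 to compound 3 (3.39 log units; beyond the scatter), while against compound 2 the step is an at least 1.1-fold higher number from compound 2 to compound 3 (0.05 log units; that floor lies within the scatter). Compound 4 `COc1ccc(-c2cc([C@@H]3O[C@H](CO)[C@@H](O)[C@H]3O)n3ncnc(N)c23)cc1` carries 4-methoxyphenyl in place of 2-fluorophenyl on an aromatic carbon. For the measured compounds named here, the steps that bear on this change are the large one from compound 1 to compound 3 and the one from compound 2 to compound 3, whose floor lies within the scatter; both aryl compounds sit far from compound 1. No step beyond the scatter is therefore expected for a number no higher from compound 3 to compound 4 (the limit leaves the size open), and a limit is again likely. Compound 4 is estimated at 100000 nM, with a range of 30000 nM to 300000 nM.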

Compound 4, half-maximal inhibitory concentration: 40300 nM
Beside the measured number, compound 4's estimate is 2.5-fold (0.39 log units) above it; the measured number falls inside the stated range.
By their numbers in this assay, from the lowest: compound 1; then compound 4; then compound 2. At a limit, above all of these: compound 3.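

In this assay, 4-methoxyphenyl in place of 2-fluorophenyl gives an at least 2.4-fold lower number from compound 3 to compound 4 (0.39 log units; beyond the scatter), a floor set by the limit of the assay held by compound 3: the limit of > 100000 nM in this assay, at which 1 of the 4 values shown sits.

The aryl groups on this aromatic carbon therefore do not all read alike, and 4-methoxyphenyl in place of 2-phenylethynyl gives a 2.2-fold lower number from compound 2 to compound 4 (0.34 log units; beyond the scatter). Against pent-1-yn-1-yl the gap stays wide, with a 1000-fold higher number from compound 1 to compound 4 (3.00 log units; beyond the scatter), so 4-methoxyphenyl recovers little of it.

Going by these compounds, it remains open whether the gain belongs to the methoxy group or to the loss of fluorine. On these data alone, how a saturated pentyl chain or an aminomethyl group would read on this carbon also remains open.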